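This account rests on a few compounds, and the source may have more. Where it says the series, first, only, none or still open, it means among the compounds named here.

In a functional assay on MEL-JUSO cells (Homo sapiens) for antiproliferative activity, read by CellTiter-Blue, with a stated time of 24 h (on this read-out higher numbers stand for an effect only at larger amounts of compound and lower numbers for an effect already at smaller amounts), compound 1 (`CS(=O)(=O)c1ccc(C(CCCCO[N+](=O)[O-])=C(c2ccc(F)cc2)c2ccc(F)cc2)cc1`) is recorded as "not determined" (no result reported). For the measured compounds named here, this leaves compound 2 (`CS(=O)(=O)c1ccc(C(CCCO)=C(c2ccc(F)cc2)c2ccc(F)cc2)cc1`), at 36300 nM, as the only number, with no measured neighbour to rank it against. Compound 3 (`CS(=O)(=O)c1ccc(C(CCCCO)=C(c2ccc(F)cc2)c2ccc(F)cc2)cc1`) has yet to be measured in this assay. Going from compound 2 to compound 3, the change is hydroxymethyl in place of hydroxy on a saturated chain carbon, three bonds along the chain from a double-bonded chain carbon, which also reads as 3-hydroxypropyl to 4-hydroxybutyl. Going by the values given here, no measured step gauges this change, so the expectation rests on compound 2 at 36300 nM and is for a slight shift toward lower numbers, probably within the usual scatter. The estimated change is a 1.3-fold lower number from compound 2 to compound 3 (0.11 log units; within the scatter). For compound 3 the expected value is 28000 nM, with an estimated range of 12000 nM to 65000 nM.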

Compound 3, half-maximal effective concentration: 34900 nM
The estimate for compound 3 lay 1.2-fold (0.10 log units) below the measured number; low and high end bracket the measured number.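

In this assay, the series now has its first readable step, a 1.0-fold lower number from compound 2 to compound 3 (0.02 log units; within the scatter), for hydroxymethyl in place of hydroxy on a saturated chain carbon, three bonds along the chain from a double-bonded chain carbon. Compound 2 alone could not show how this position responds; the change from 3-hydroxypropyl to 4-hydroxybutyl stays within the usual scatter, so this one added chain unit separates the two compounds by no readable amount. No supporting data bear on this result.

Still open, on these data alone, is whether a longer chain than 4-hydroxybutyl, or an amine or a carboxylic acid in place of the hydroxy, would move the number beyond the scatter. Compound 1 carries a nitrate ester in place of the hydroxy of compound 3, but with no result reported, that step cannot be read.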